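Removing one methoxy from the dimethoxyphenyl of compound 2

The source may report more compounds than this note shows. Statements on the series, on what has been measured and on what is new or still open speak of the compounds shown alone.

Compound 2 `COc1ccc(C(=O)/C=C/c2cc(-c3cc(OC)c(OC)c(OC)c3)n[nH]2)cc1OC` gives -97% in a functional assay on UO-31 cells (Homo sapiens) for cytotoxicity, read by sulforhodamine B assay, with a stated time of 48 h, tested at 10 uM (a higher number here means a weaker effect of the compound at the concentration tested, a lower number a stronger effect), and stands lowest of the two numbers recorded; the nearest is compound 1 `COc1cc(-c2cc(/C=C/C(=O)c3ccc(N)cc3)[nH]n2)cc(OC)c1OC`, which gives -84%. For the measured compounds named here, the one measured step, a number 13 percentage points lower from compound 1 to compound 2 (beyond the scatter), concerns an aryl swap on the carbonyl carbon. Compound 3 `COc1ccc(C(=O)/C=C/c2cc(-c3cc(OC)c(OC)c(OC)c3)n[nH]2)cc1` differs from compound 2 by hydrogen in place of methoxy on an aromatic carbon. Going by the values given here, no measured step touches a single methoxy, so only the aryl swap offers a loose guide, and it was modest. For compound 3 the expected step is a number 7 percentage points higher from compound 2 to compound 3 (within the scatter), a small weakening at most. Compound 3 is estimated at -90%, within -100% to -72%.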

Compound 3, a percentage reported as activity, at one concentration (the size of the read-out at that concentration, not a potency): -93%
Beside the measured number, compound 3's estimate is 3 percentage points above it; measured number inside the range.
By their numbers in this assay, from the lowest: compounds 2, 3 and 1 (each within the scatter of the next, the first and the last beyond it).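

In this assay, the change from 3,4-dimethoxyphenyl to 4-methoxyphenyl gives a number 4 percentage points higher from compound 2 to compound 3 (within the scatter), so this methoxy can be lost without a change beyond the scatter. Methoxy in place of amino gives a number 9 percentage points lower from compound 1 to compound 3 (within the scatter), which is also within the scatter, whereas the swap to 3,4-dimethoxyphenyl in the earlier pair lay beyond it. No measurement here offers an explanation for these results. On these data alone, whether the remaining methoxy can also be lost, or replaced by a hydroxyl or a chlorine, stays open. These numbers describe the size of the effect at a single concentration only, and how the compounds would compare at other concentrations stays unresolved.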